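The compounds below may be only part of what the source reports. "The series", "measured", "known", "first", "only" and "open" are said of these compounds alone.

For the measured compounds named here, compound 2 `Cc1c(OCCCCOc2ccc(C(=O)O)cc2F)ccc(C(=O)CC(C)(C)C)c1O` gives 75 nM in an assay for positive allosteric modulation of metabotropic glutamate receptor 2 (Rattus norvegicus) (on this read-out lower numbers stand for an effect already at smaller amounts and higher numbers for an effect only at larger amounts of compound), the highest of the two numbers known so far; compound 1 `Cc1ncc(OCCCCOc2ccc(C(=O)CC(C)(C)C)c(O)c2C)cc1C(=O)O` gives 28 nM. Compound 3 `COc1ccc(OCCCCOc2ccc(C(=O)CC(C)(C)C)c(O)c2C)cc1` has not been measured and differs from compound 2 by 4-methoxyphenyl in place of 4-carboxy-2-fluorophenyl on an oxygen on a saturated carbon. Going by the values given here, the only measured step at this position, a 2.7-fold higher number from compound 1 to compound 2 (0.43 log units; beyond the scatter), already raised the number beyond the scatter with a carboxy group retained on both sides, so for this larger change the step is expected to run in the same direction and somewhat further, as a 2.9-fold higher number from compound 2 to compound 3 (0.47 log units; beyond the scatter). Compound 3 is therefore estimated at 220 nM, within a range from 60 nM to 800 nM.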

Compound 3, half-maximal effective concentration: > 10000 nM
Compound 3: only a limit was reported; the forecaster's own chance of this, stated with the estimate: 10%; middle value at least 45-fold (1.65 log units) away from the limit.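

In this assay compound 3 is reported only as a limit, > 10000 nM. Read against that limit, this position proves far less forgiving than the earlier pair showed: an at least 130-fold higher number from compound 2 to compound 3 (2.12 log units; beyond the scatter) and an at least 350-fold higher number from compound 1 to compound 3 (2.55 log units; beyond the scatter), both large where the step between the two carboxy-bearing groups was modest. Of the three compounds, the two with a carboxy group give a measured number, and the one with 4-methoxyphenyl does not.

From the compounds shown here alone, how far compound 3 lies past its limit stays open: the limit of > 10000 nM in this assay, at which 1 of the 3 values shown sits. Also open is whether the carboxylic acid itself is required, or whether a tetrazole, a primary amide or a 4-hydroxyphenyl group would give a measurable number.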